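The source may hold more compounds than are shown below. What is called first, only, known or untested is meant among the compounds shown, and "the series" means these compounds.

Measured compounds:
compound 1 `Nc1nc(-c2ccco2)nc2sc(CNC3CC3)cc12`, in an assay on CHO-K1 cells for antagonist activity at adenosine receptor A1 (Homo sapiens), read by a beta-galactosidase reporter, with stated times of 15 min and 6 h (a higher number here means a weaker inhibitor, a lower number a stronger inhibitor), compound 1 gives 1890 nM
compound 2 `Nc1nc(-c2ccco2)nc2sc(CN3CCC(F)CC3)cc12`, compound 2 gives 740 nM
compound 3 `CCc1ccc(-c2nc(N)c3cc(CN4[C@H](C)CCC[C@@H]4C)sc3n2)o1`, compound 3 gives 190 nM

Compound 3 has the lowest number of the three, with compound 2 nearest to it and compound 1 furthest. Compound 4 `C[C@@H]1CCC[C@H](C)N1Cc1cc2c(N)nc(-c3ccc(C4CC4)o3)nc2s1` differs from compound 3 by cyclopropyl in place of ethyl on an aromatic carbon. Within the data shown here, the single measured step, a 2.6-fold lower number from compound 1 to compound 2 (0.41 log units; beyond the scatter), concerns the amine on a saturated chain carbon and not the furan substituent, so no step on record speaks to the ethyl-to-cyclopropyl exchange. The change is expected to yield no step beyond the scatter, estimated as no change at the digits printed from compound 3 to compound 4 (within the scatter). Compound 4 is therefore estimated at 190 nM, with an expected range from 80 nM to 450 nM.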

Compound 4, inhibition constant: 330 nM
Compound 4: middle estimate off by 1.7-fold (0.24 log units), on the low side, within the range that was stated.
By their numbers in this assay, from the lowest: compounds 3 and 4 (each within the scatter of the next); then compound 2; then compound 1.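

Cyclopropyl in place of ethyl gives the first reading at the furan carbon next to the ring oxygen: in this assay the step is a 1.7-fold higher number from compound 3 to compound 4 (0.24 log units; within the scatter) and lies within the scatter. With the amine of compound 3 held fixed, this assay does not separate 5-ethylfuran-2-yl from 5-cyclopropylfuran-2-yl. No measurement at hand offers an explanation for this result.

The step from the unsubstituted furan to either group cannot be read, since compounds 1 and 2 also carry other amines. Open too, from the compounds shown here alone, is how a longer chain such as n-butyl, or a methoxy group, would read at this carbon.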